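Amino to chloro on the shared core: compound 1 to compound 3

The source may hold more compounds than are shown below. What is called first, only, known or untested is meant among the compounds shown, and "the series" means these compounds.

Compound 1 `Nc1nc(Cl)c2ncn(Cc3ccccc3CCl)c2n1` and compound 2 `ClCc1ccccc1Cn1cnc2ncnc(Cl)c21` have been measured in a functional assay on RPMI-8226 cells (Homo sapiens) for cytotoxicity, read by sulforhodamine B assay, with a stated time of 48 h; a higher number here means a weaker inhibitor of growth, a lower number a stronger inhibitor of growth. Compound 1 gives 11200 nM, the highest of the two numbers, while compound 2 gives 2080 nM; the gap between them lies beyond the scatter. Compound 3 `ClCc1ccccc1Cn1cnc2c(Cl)nc(Cl)nc21` is not yet measured; it differs from compound 1 by chloro in place of amino on an aromatic carbon. Among the measured compounds shown here, no single-point step between measured compounds is available. Given that compound 2, which lacks the amino group, gives 2080 nM, a step toward lower numbers of a 3.7-fold lower number from compound 1 to compound 3 (0.57 log units; beyond the scatter) is expected in this assay. Compound 3 is estimated at 3000 nM, in the range 1000 nM to 9000 nM.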

Compound 3, concentration for 50% growth inhibition: 380 nM
The estimate for compound 3 lay 7.9-fold (0.90 log units) above the measured number; the measured number lies below the stated range.
By their numbers in this assay, from the lowest: compound 3; then compound 2; then compound 1.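

At the position between two ring nitrogen atoms, chloro in place of amino gives a large move in this assay, a 29-fold lower number from compound 1 to compound 3 (1.47 log units; beyond the scatter), so this position strongly affects the number. Loss of amino alone does not appear to be the whole story: compound 2, which lacks the amino group, gives 2080 nM, while compound 3, which carries chloro there, gives 380 nM.

On these data alone, whether a methoxy group or a fluoro group at this position would match chloro remains open. Nothing at hand accounts for the size of this step.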